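Swapping hydroxymethyl for methoxy on an amine side chain

The compounds below may be only part of what the source reports. "The series", "measured", "known", "first", "only" and "open" are said of these compounds alone.

Compound 1 `COc1cc(/C=C/C(=O)/C=C(/C=C/c2ccc(O)c(OC)c2)NCCO)ccc1O` gives > 100000 nM
Compound 2 `COc1cc(/C=C/C(=O)/C=C(/C=C/c2ccc(O)c(OC)c2)NCCCO)ccc1O` gives > 100000 nM

In a functional assay on HT-29 cells (Homo sapiens) for cytotoxicity, read by MTT assay, with a stated time of 48 h (on this read-out higher numbers stand for weaker inhibition and lower numbers for stronger inhibition), compound 2 stands only at a limit (> 100000 nM) and has no exact number. Compound 1 also reaches only a limit (> 100000 nM). Both compounds therefore share one ceiling (the limit of > 100000 nM in this assay, at which 2 of the 2 values shown sit).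

Compound 3 `COCCNC(=C\C(=O)/C=C/c1ccc(O)c(OC)c1)/C=C/c1ccc(O)c(OC)c1` has the same atoms as compound 2, joined differently (methoxy in place of hydroxymethyl on a saturated chain carbon, two bonds along the chain from an amine nitrogen). Methoxy takes the place of hydroxymethyl on a saturated chain carbon, two bonds along the chain from an amine nitrogen. For the measured compounds named here, the one measured step at this place (a step that the two limits leave unreadable from compound 1 to compound 2) has no readable size, so it offers no direction. The expected step (a number no higher from compound 2 to compound 3 (the limit leaves the size open)) is therefore none beyond the scatter, and another limit is likely. For compound 3 the estimated value is 100000 nM, with an expected range of 40000 nM to 200000 nM.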

Compound 3, half-maximal inhibitory concentration: > 100000 nM
Compound 3: a limit, no number; the forecaster's own chance of this, stated with the estimate: 80%; the middle value lies on the limit itself.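

No step can be read among compound 1, compound 2 and compound 3 in this assay, because each value is only a limit: the limit of > 100000 nM in this assay, at which 3 of the 3 values shown sit.

The compounds shown leave open whether (3-hydroxypropyl)amino and (2-methoxyethyl)amino differ at all in this read-out, since none gives an exact number.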